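This account rests on a few compounds, and the source may have more. Where it says the series, first, only, none or still open, it means among the compounds named here.

In an assay for binding affinity to 17-beta-hydroxysteroid dehydrogenase type 2 (Homo sapiens), with a stated time of 20 min, tested at 1 uM (a lower number here means less inhibition, a higher number more inhibition at the concentration tested (going by the name of the read-out)), compound 1 `N#Cc1ccc(-c2ccc3c(O)cccc3c2)cc1` gives 12%. Compound 2 `CC(=O)c1ccc(-c2ccc3c(O)cccc3c2)cc1` returns only an assay limit, < 10%. Compound 2 therefore stands at the floor of the measured numbers, as shown by the limit of < 10% in this assay, at which 1 of the 2 values shown sits, and the step of a number at least 2 percentage points lower from compound 1 to compound 2 (that floor lies within the scatter) is bounded on one side only. Compound 3 `O=C(O)c1ccc(-c2ccc3c(O)cccc3c2)cc1` differs from compound 2 in one place: hydroxy in place of methyl on a carbonyl carbon. For the measured compounds named here, no measured step covers this change, and the single known step in this assay is small. No shift beyond the scatter is expected for compound 3, estimated at 6% with a range of 0% to 15%. The expected step is a step that the limit leaves unreadable from compound 2 to compound 3.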

Compound 3, a percentage reported as inhibition, at one concentration (the size of the read-out at that concentration, not a potency): 16%
The estimate for compound 3 lay 10 percentage points below the measured number; the whole stated range lies below it.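

In this assay hydroxy in place of methyl on a carbonyl carbon, the change from acetyl to carboxy, can be read only as a floor (a number at least 6 percentage points higher from compound 2 to compound 3 (that floor lies within the scatter)). That step is bounded on one side only: the limit of < 10% in this assay, at which 1 of the 3 values shown sits.

Swapping the cyano group for a carboxy group gives a step that can be read in full (a number 4 percentage points higher from compound 1 to compound 3 (within the scatter)), so compound 1 and compound 3 cannot be told apart at this place.

Going by these compounds, whether an amine or a longer chain at this place would shift the inhibition beyond the scatter stays open. Potency also stays open, as each reading comes from one concentration.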